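The source may report more compounds than this note shows. Statements on the series, on what has been measured and on what is new or still open speak of the compounds shown alone.

Measured in a functional assay on PC-3 cells (Homo sapiens) for antiproliferative activity, read by WST assay, with a stated time of 3 days; on this read-out lower numbers stand for stronger inhibition and higher numbers for weaker inhibition:
- compound 1 `CCOc1c(-c2cc(OC)c(OC)c(OC)c2)oc2ccccc2c1=O`: 900 nM
- compound 2 `CCCCCOc1c(-c2cc(OC)c(OC)c(OC)c2)oc2ccccc2c1=O`: 22200 nM
- compound 3 `CCCN(CCC)CCCCCOc1c(-c2cc(OC)c(OC)c(OC)c2)oc2ccccc2c1=O`: 2600 nM

Compound 3 holds the middle place among these numbers, as shown by a 2.9-fold higher number from compound 1 to compound 3 (0.46 log units; beyond the scatter) and an 8.5-fold lower number from compound 2 to compound 3 (0.93 log units; beyond the scatter). The next compound is compound 4 `CCCCCN(CCCCC)CCCOc1c(-c2cc(OC)c(OC)c(OC)c2)oc2ccccc2c1=O`, and its difference is dipentylamino in place of 2-(dipropylamino)ethyl on a saturated chain carbon, three bonds along the chain from an oxygen on an aromatic ring. In words, this is dipentylamino in place of 2-(dipropylamino)ethyl on a saturated chain carbon, three bonds along the chain from an oxygen on an aromatic ring.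

Among the measured compounds shown here, no measured step makes this exact change. The closest evidence concerns the chain: propyl alone gave a 25-fold higher number from compound 1 to compound 2 (1.39 log units; beyond the scatter), while adding dipropylamino gave an 8.5-fold lower number from compound 2 to compound 3 (0.93 log units; beyond the scatter). Compound 4 also carries a dialkylamino group, so compound 3 at 2600 nM is its best guide. For the measured compounds named here, no measured pair separates where the amino group sits from what it carries, so no step beyond the scatter is expected in this assay. The expected change is a 1.2-fold higher number from compound 3 to compound 4 (0.06 log units; within the scatter). For compound 4 the estimated value is 3000 nM, with an expected range from 1000 nM to 9000 nM.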

Compound 4, half-maximal inhibitory concentration: 5800 nM
For compound 4 the middle estimate is 1.9-fold (0.29 log units) below the measured one; low and high end bracket the measured number.
By their numbers in this assay, from the lowest: compound 1; then compound 3; then compound 4; then compound 2.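

In this assay, dipentylamino in place of 2-(dipropylamino)ethyl, on a saturated chain carbon three bonds along the chain from an oxygen on an aromatic ring, gives a 2.2-fold higher number from compound 3 to compound 4 (0.35 log units; beyond the scatter), so this rearrangement of the amine side chain costs a modest amount of activity. A second dialkylamino compound now also improves on the plain alkyl chain, with a 3.8-fold lower number from compound 2 to compound 4 (0.58 log units; beyond the scatter), yet it stays weaker than the small ethyl ether, with a 6.4-fold higher number from compound 1 to compound 4 (0.81 log units; beyond the scatter). No outside evidence accounts for these differences.

This swap alters both the chain leading to the nitrogen and the groups on that nitrogen, and the two contributions cannot be told apart. On these data alone, how dimethylamino or a ring amine such as piperidine would behave on these chains remains open.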